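Swapping phenyl for methyl on compound 2

The compounds below may be only part of what the source reports. "The series", "measured", "known", "first", "only" and "open" are said of these compounds alone.

Compound 1 `Fc1ccc(-c2nc(-c3ccc4nc[nH]c4c3)no2)cc1F` (3.3)
Compound 2 `Fc1ccc(-c2nc(-c3ccc(-c4ccccc4)cc3)no2)cc1F` (4.75)

These two compounds were measured in a physicochemical assay for lipophilicity, using potentiometric titration, at pH 7.4; a lower number here means a more polar compound, a higher number a more lipophilic compound. Compound 2 stands highest of the two (4.75), and the gap down to compound 1 (3.3) lies beyond the scatter of repeated measurements.

The next compound, compound 3 `Cc1ccc(-c2noc(-c3ccc(F)c(F)c3)n2)cc1`, has not been measured yet. It differs from compound 2 in one place, with methyl in place of phenyl on an aromatic carbon, para to a large group (methyl in place of phenyl on an aromatic carbon).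

Going by the values given here, no two measured compounds differ in just one place, so no measured step can guide this change, and the expectation is a judgement from the structures alone. A downward step beyond the scatter is expected (a number 0.85 log units lower from compound 2 to compound 3 (beyond the scatter)). For compound 3 the estimated value in this assay is 3.9, with an expected range from 3.4 to 4.4.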

Compound 3, distribution coefficient: 4.16
Beside the measured number, compound 3's estimate is 0.26 log units below it; the measured number falls inside the stated range.
By their numbers in this assay, from the lowest: compound 1; then compound 3; then compound 2.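

In this assay, replacing phenyl with methyl on this aromatic carbon, para to a large group, gives a number 0.59 log units lower from compound 2 to compound 3 (beyond the scatter). Going by these compounds alone, this is the first change here that can be read at a single place, and it shows that the number responds to what sits at this position, even though the change removes one six-membered aromatic ring of carbon only and adds no hydrogen-bond donors, hydrogen-bond acceptors or net charge. Nothing measured here explains why the number moves by this amount.

With only methyl and phenyl compared at this position, a single step cannot show how the number follows the group placed there. Going by these compounds, a longer chain such as propyl, an amine or a carboxylic acid at the same carbon remains open, as does whether this step would carry over to another core.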